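The compounds below may be only part of what the source reports. "The series", "measured", "known", "first", "only" and "open" are said of these compounds alone.

Of the compounds shown here, two built on the same core have been tested in a functional assay on HepG2 cells (Homo sapiens) for inhibition, read by MTT assay, with a stated time of 48 h (on this read-out higher numbers stand for weaker inhibition and lower numbers for stronger inhibition), so far. Compound 1, `CCOC(=O)C1=C(N/N=C(/Br)c2ccccc2)Nc2[nH]nc(C)c2C1c1ccc(N(C)C)cc1`, gives 72000 nM in this assay. Compound 2, `CCOC(=O)C1=C(N/C=N/c2ccccn2)Nc2[nH]nc(C)c2C1c1ccc(N(C)C)cc1`, gives 26200 nM. Among the compounds with values here, the single measured step, a 2.7-fold lower number from compound 1 to compound 2 (0.44 log units; beyond the scatter), exchanges the group attached to the amine nitrogen at the edge of the core. On the numbers shown, compound 2 stands lowest of the two, with compound 1 the only neighbour at a higher number.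

Compound 3, `CCOC(=O)C1=C(N/N=C(/Cl)C#N)Nc2[nH]nc(C)c2C1c1ccc(N(C)C)cc1`, changes that same edge again: a group of 5 heavy atoms (2 carbon, 2 nitrogen, 1 chlorine; no ring) in place of a group of 8 heavy atoms (6 carbon, 2 nitrogen; one six-membered aromatic ring with 1 hetero atom), on an amine nitrogen. Within the data shown here, the only step that bears on this position is the one from compound 1 to compound 2, and it was modest in size. Compound 3 returns to a group joined through two nitrogens, as compound 1 was, though with a much smaller group and no ring, so the most that can be read from the data is that a change at this spot shifts the number only modestly; a return toward the higher number of compound 1 seems somewhat more likely than a further drop. Compound 3 is therefore expected to come out near 50000 nM in this assay, within a range of about 15000 nM to 160000 nM, which means an expected step of a 1.9-fold higher number from compound 2 to compound 3 (0.28 log units; within the scatter).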

Compound 3, half-maximal inhibitory concentration: 23600 nM
The estimate for compound 3 lay 2.1-fold (0.33 log units) above the measured number, within the range that was stated.
By their numbers in this assay, from the lowest: compounds 3 and 2 (each within the scatter of the next); then compound 1.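

In this assay, replacing the group with the six-membered aromatic ring by the smaller group with no ring gives a 1.1-fold lower number from compound 2 to compound 3 (0.05 log units; within the scatter), so this change on the amine nitrogen leaves compound 2 and compound 3 indistinguishable. Within the data shown here, the ring in compound 2 is therefore not required to reach this level, at least when the group that enters is the one in compound 3. The other new comparison gives a 3.1-fold lower number from compound 1 to compound 3 (0.48 log units; beyond the scatter), which shows that being joined through two nitrogens, as in compound 1, does not by itself bring the higher number back, and no measurement shown here explains these results.

On these data alone, what remains open is whether any group on this amine nitrogen can move the number well beyond the modest steps seen so far, as a simple primary amine, a carboxylic acid or a longer alkyl chain might or might not do. These three compounds also cannot separate the roles of the chlorine and the nitrile in compound 3, since the two differ from the bromine and the phenyl ring of compound 1 together.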